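Chloro compound 3 and a change of side chain

The source may report more compounds than this note shows. Statements on the series, on what has been measured and on what is new or still open speak of the compounds shown alone.

Compound 1 `CN(C)CCn1c(N)c(-c2nc3ccccc3[nH]2)c2nc(C#N)c(C#N)nc21` gives 2220 nM
Compound 2 `CN(C)CCCn1c(N)c(-c2nc3ccccc3o2)c2nc(C#N)c(C#N)nc21` gives 390 nM
Compound 3 `CN(C)CCn1c(N)c(-c2nc3cc(Cl)ccc3[nH]2)c2nc(C#N)c(C#N)nc21` gives > 50000 nM

All three values come from a functional assay on HL-60 cells (Homo sapiens) for antiproliferative activity, read by MTT assay, with a stated time of 48 h (on this read-out higher numbers stand for weaker inhibition and lower numbers for stronger inhibition), and are compared here. Compound 3 has no exact value, only a limit (> 50000 nM).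

Compound 4 `CCN(CC)CCCn1c(N)c(-c2nc3cc(Cl)ccc3[nH]2)c2nc(C#N)c(C#N)nc21` keeps the chloro group and changes the side chain, with (diethylamino)methyl in place of dimethylamino on a saturated chain carbon, two bonds along the chain from an aromatic nitrogen as the difference. Cut one bond further out, this reads 2-(dimethylamino)ethyl to 3-(diethylamino)propyl.

Among the compounds with values here, only one measured step bears on this pair. That large step, an at least 22-fold higher number from compound 1 to compound 3 (1.35 log units; beyond the scatter), lies beyond the scatter, but it concerns the chloro group and not the chain. Within the data shown here, no measured step isolates the chain, so any forecast is loose. Compound 1 at 2220 nM and compound 2 at 390 nM show that related compounds can give real numbers in this assay, so a move toward stronger inhibition is expected. Compound 4 may also stay at the limit.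

The expected change is an at least 6.2-fold lower number from compound 3 to compound 4 (0.79 log units; beyond the scatter) and remains only an estimate.

For compound 4 the estimated value is 8000 nM (expected range 1000 nM to 50000 nM).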

Compound 4, half-maximal inhibitory concentration: 3470 nM
Estimate against measurement, compound 4: 2.3-fold (0.36 log units) above; the measured number falls inside the stated range.
By their numbers in this assay, from the lowest: compound 2; then compounds 1 and 4 (each within the scatter of the next). At a limit, above all of these: compound 3.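

Replacing the 2-(dimethylamino)ethyl chain with 3-(diethylamino)propyl while keeping the chloro group gives an at least 14-fold lower number from compound 3 to compound 4 (1.15 log units; beyond the scatter) in this assay, so the side chain on the aromatic nitrogen has a large influence on this read-out. Within the data shown here, the earlier compounds showed only the step that came with adding chloro, and compound 4 now shows that a chloro compound can still give a measured value here. Compound 3 has only a limit, so this step has a minimum size and not an exact one: the limit of > 50000 nM in this assay, at which 1 of the 4 values shown sits.

This change lengthens the chain and swaps dimethylamino for diethylamino in one move, and the compounds shown cannot separate these two parts. A 2-(diethylamino)ethyl chain on the chloro compound would isolate the amine, and a 4-(diethylamino)butyl chain would test a longer chain.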